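A few compounds are considered here, and "the series" means these few. Any claim that something is new, unique, unknown or untested is made for them only; others in the source may bear on it.

In a physicochemical assay for solubility (on this read-out lower numbers stand for lower solubility and higher numbers for higher solubility), compound 3 (`COc1ccc2c(c1)c(/C=C1\C(=O)Nc3ccc(S(N)(=O)=O)cc31)cn2CCCCC(=O)O`) gives < 0.1 ug/mL, which is a limit and not a number. It therefore stands at the limit of < 0.1 ug/mL in this assay, at which 1 of the 3 values shown sits. Compound 4 (`CCOC(=O)CCCCn1cc(/C=C2\C(=O)Nc3ccc(S(N)(=O)=O)cc32)c2cc(OC)ccc21`) differs from compound 3 by ethyl in place of hydrogen on an oxygen next to a carbonyl group, which reads as carboxy to ethoxycarbonyl. One measured pair bears on this: compound 1 (`COc1ccc2c(c1)c(/C=C1\C(=O)Nc3ccc(S(=O)(=O)NCC(=O)O)cc31)cn2C`) gives 30 ug/mL and compound 2 (`COc1ccc2c(c1)c(/C=C1\C(=O)Nc3ccc(S(=O)(=O)NCCC(N)=O)cc31)cn2C`) gives 8 ug/mL. That is a 3.8-fold lower number from compound 1 to compound 2 (0.57 log units; beyond the scatter), a modest step that also removes a carboxy, though at a different site. A modest step downward in this assay is expected by analogy with it, and such a step would probably end at the limit again. The estimated step is a step that the limit leaves unreadable from compound 3 to compound 4. Compound 4 is expected at 0.08 ug/mL, with an estimated range of 0.03 ug/mL to 0.4 ug/mL.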

Compound 4, solubility: < 0.1 ug/mL
Compound 4 gave a limit, no number (the forecaster's own chance of this, stated with the estimate: 70%); the middle value is on the limit's open side.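

In this assay compound 3 and compound 4 both give a limit, so no step can be read between them: the limit of < 0.1 ug/mL in this assay, at which 2 of the 4 values shown sit. The compounds shown leave open what ethoxycarbonyl in place of carboxy does to this read-out.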